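The source may report more compounds than this note shows. Statements on the series, on what has been measured and on what is new or still open speak of the compounds shown alone.

Measured so far in a functional assay with Homo sapiens as the target, in the presence of a further agent that is not named here; a lower number here means a stronger inhibitor, a higher number a weaker inhibitor:
- compound 1 `CC(C)[C@H](NC(=O)[C@H](CC(=O)O)NC(=O)CCCOc1ccc(C(=N)N)cc1)C(=O)N1CCOCC1`: 79 nM
- compound 2 `CC(C)[C@H](NC(=O)[C@H](CC(=O)O)NC(=O)CCCOc1ccc(C(=N)N)cc1)C(=O)O`: 100 nM

Compound 2 carries a carboxy group where compound 1 has morpholin-4-yl on the same carbonyl carbon. The numbers of these two compounds lie within the scatter of each other, so they cannot be ranked. Compound 3 `CC(C)[C@H](NC(=O)[C@H](CC(=O)O)NC(=O)CCCOc1ccc(C(=N)N)cc1)C(=O)N1CCN(C)CC1` has not been measured yet. It has 4-methylpiperazin-1-yl in place of hydroxy on a carbonyl carbon.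

Among the measured compounds shown here, only one measured step bears on this change, and it sits at the same place. Because a 1.3-fold higher number from compound 1 to compound 2 (0.10 log units; within the scatter) is all that exchange produced, no step beyond the scatter is expected here, in either direction. One step is thin evidence, so the range is kept wide.

Compound 3 is estimated at 90 nM, with an expected range of 35 nM to 230 nM. This estimate means an expected 1.1-fold lower number from compound 2 to compound 3 (0.05 log units; within the scatter).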

Compound 3, half-maximal inhibitory concentration: 180 nM
Estimate against measurement, compound 3: 2.0-fold (0.30 log units) below; measured number inside the range.
By their numbers in this assay, from the lowest: compounds 1, 2 and 3 (each within the scatter of the next, the first and the last beyond it).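

In this assay, among the compounds shown here, the step of a 2.3-fold higher number from compound 1 to compound 3 (0.36 log units; beyond the scatter) is the first exchange on this carbonyl carbon to go beyond the usual scatter, though only modestly, so the choice of group here can matter a little. Set against hydroxy, the same 4-methylpiperazin-1-yl group gives a 1.8-fold higher number from compound 2 to compound 3 (0.26 log units; within the scatter) and stays within the scatter, so compound 2 and compound 3 cannot be ranked, and compound 2 cannot be ranked against compound 1 either. No measurement is available that would account for the step between the two ring-bearing compounds.

Still open, on these data alone, is whether the methyl on the ring contributes to that step, which a plain piperazin-1-yl group would test. As far as these compounds go, it is also open whether an open-chain amide, such as one made from dimethylamine, would behave like the ring-bearing groups.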